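The source may report more compounds than this note shows. Statements on the series, on what has been measured and on what is new or still open speak of the compounds shown alone.

Working notes on the series. The shared core of compound 1 `Nc1scc(CN2CCN(c3cccc(C(F)(F)F)c3)CC2)c1C(=O)c1ccc(Cl)cc1` and compound 2 `Nc1scc(CN2CCN(c3ccc(OC(F)(F)F)cc3)CC2)c1C(=O)c1ccc(Cl)cc1` is varied only at the group on the amine nitrogen in the ring. For the measured compounds named here, in a functional assay on CHO cells with adenosine receptor A1 (Homo sapiens) as the target, read by cAMP accumulation and immunoassay, with a stated time of 6 min, tested at 1 uM (a higher number here means a weaker effect of the compound at the concentration tested, a lower number a stronger effect), compound 1 gives -72% and compound 2 gives -51%; the one measured step is a number 21 percentage points higher from compound 1 to compound 2 (beyond the scatter), so compound 2 stands highest of the two numbers, with compound 1 as its only neighbour.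

Compound 3 `Nc1scc(CN2CCN(c3cccnc3)CC2)c1C(=O)c1ccc(Cl)cc1` is not yet measured. It differs from compound 2 by pyridin-3-yl in place of 4-(trifluoromethoxy)phenyl on an amine nitrogen in a ring. Going by the values given here, the single step that bears on this change is the exchange of one aryl group for another on the same ring nitrogen, a number 21 percentage points higher from compound 1 to compound 2 (beyond the scatter), which is modest but beyond the scatter and ran toward weaker effect. Among the compounds with values here, the pyridin-3-yl group has no precedent among the measured compounds, so any expectation rests on that one step alone. A further move in the same direction is expected, of roughly a number 16 percentage points higher from compound 2 to compound 3 (beyond the scatter), though a result within the scatter of compound 2 cannot be excluded. In this assay compound 3 is therefore estimated at -35%, with a range from -65% to 0%.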

Compound 3, a percentage reported as activity, at one concentration (the size of the read-out at that concentration, not a potency): -2.7%
Compound 3: middle estimate off by 32.3 percentage points, on the low side, within the range that was stated.
By their numbers in this assay, from the lowest: compound 1; then compound 2; then compound 3.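

In this assay, the group on the amine nitrogen in the ring turns out to have a much larger effect on the read-out than the exchange between the two fluorinated aryl groups indicated, which gave only a number 21 percentage points higher from compound 1 to compound 2 (beyond the scatter), whereas pyridin-3-yl in place of 4-(trifluoromethoxy)phenyl gives a number 48.3 percentage points higher from compound 2 to compound 3 (beyond the scatter). Pyridin-3-yl in place of 3-(trifluoromethyl)phenyl gives a number 69.3 percentage points higher from compound 1 to compound 3 (beyond the scatter), so compound 3 has the weakest effect of the three at the concentration tested, and the size of the aryl exchange at this position clearly matters more than the first step alone could show. No measurement at hand accounts for this loss of effect.

The change from compound 2 to compound 3 removes the trifluoromethoxy group, reduces the group from 11 heavy atoms to 6 and puts a nitrogen into the aromatic ring, all in one step, so the compounds shown leave open which of these differences carries the shift. An unsubstituted phenyl group, or a pyridin-3-yl group bearing a trifluoromethyl group, on the same ring nitrogen would separate the ring nitrogen from the loss of the fluorinated substituent.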